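The source may report more compounds than this note shows. Statements on the series, on what has been measured and on what is new or still open speak of the compounds shown alone.

Values in a functional assay (CEM-VLB cells, Homo sapiens) for antiproliferative activity, read by sulforhodamine B assay, with a stated time of 48 h; on this read-out lower numbers stand for stronger inhibition and higher numbers for weaker inhibition:
- compound 1 `CCc1cccc(NS(=O)(=O)c2ccc(N3CCNC3=O)cc2)c1`: 450 nM
- compound 2 `O=C1NCCN1c1ccc(S(=O)(=O)Nc2cccc(Br)c2)cc1`: 250 nM
- compound 3 `COc1cc(NS(=O)(=O)c2ccc(N3CCNC3=O)cc2)cc(OC)c1`: 1010 nM

Compound 1 lies within the scatter of compound 2 and clearly under compound 3. The next compound is compound 4 `COc1cccc(NS(=O)(=O)c2ccc(N3CCNC3=O)cc2)c1`, reached by methoxy in place of ethyl on an aromatic carbon. Among the measured compounds shown here, the only measured step at this place is a 1.8-fold lower number from compound 1 to compound 2 (0.26 log units; within the scatter), and it involves bromo, not methoxy. Compound 3, which also bears methoxy, gives 1010 nM, so a slight shift toward weaker inhibition in this assay is expected, but no step beyond the scatter. The expected step is a 1.3-fold higher number from compound 1 to compound 4 (0.12 log units; within the scatter). For compound 4 the estimated value is 600 nM, with an expected range of 300 nM to 1200 nM.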

Compound 4, half-maximal inhibitory concentration: 700 nM
Beside the measured number, compound 4's estimate is 1.2-fold (0.07 log units) below it, within the range that was stated.
By their numbers in this assay, from the lowest: compounds 2, 1, 4 and 3 (each within the scatter of the next, the first and the last beyond it).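

In this assay, the swap from ethyl to methoxy at this place stays within the scatter (a 1.6-fold higher number from compound 1 to compound 4 (0.19 log units; within the scatter)), as does the loss of the second methoxy (a 1.4-fold lower number from compound 3 to compound 4 (0.16 log units; within the scatter)). Among the compounds shown here, the one step here that clears the scatter is the modest one between bromo and methoxy (a 2.8-fold higher number from compound 2 to compound 4 (0.45 log units; beyond the scatter)), so the choice of group at this place registers, though only slightly. Nothing available explains that difference.

On these data alone, whether chloro would track bromo remains open. So does the response to an amine or a carboxylic acid at this place.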